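The source may hold more compounds than are shown below. What is called first, only, known or untested is meant among the compounds shown, and "the series" means these compounds.

Compounds measured so far:
compound 1, `CCOC(=O)c1cnc2n(c1=O)C(C)CC/C2=N\Nc1cccc(C(=O)O)c1`, 100 umol/kg
compound 2, `CC1CC/C(=N\Nc2ccc(O)cc2)c2ncc(C(=O)O)c(=O)n21`, 1.7 umol/kg
compound 3, `C[C@@H]1CC/C(=N\Nc2ccc(O)cc2)c2ncc(C(=O)O)c(=O)n21`, 0.14 umol/kg

In a functional assay on the whole organism for inhibition, with Rattus norvegicus as the target (a lower number here means that less compound is needed, a higher number that more compound is needed for the effect), compound 3 gives the lowest number of the three, with compound 2 nearest and compound 1 furthest. Compound 4, `C[C@H]1CC/C(=N\Nc2ccc(O)cc2)c2ncc(C(=O)O)c(=O)n21`, is not yet measured; it differs from compound 3 as follows: the two compounds have the same atoms and bonds and differ only in configuration as drawn: 1 of 2 stereo elements differ; a stereocentre at a saturated ring carbon is drawn R in compound 3 and S in compound 4. Among the measured compounds shown here, the only measured step that bears on this is a 12-fold lower number from compound 2 to compound 3 (1.08 log units; beyond the scatter), which is large and rests on the fact that one of compounds 2 and 3 is drawn with a defined configuration and the other without, at the place where they differ: compound 2 carries both arrangements at that ring carbon, compound 3 only one. Since compound 3 alone gives a much lower number than compound 2, the other arrangement in compound 4 is expected to give a higher number, a 43-fold higher number from compound 3 to compound 4 (1.63 log units; beyond the scatter). Compound 4 is therefore estimated at 6 umol/kg, within 1 umol/kg to 60 umol/kg.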

Compound 4, dose for 50% inhibition: 111 umol/kg
The estimate for compound 4 lay 19-fold (1.27 log units) below the measured number; the measured number lies above the stated range.
By their numbers in this assay, from the lowest: compound 3; then compound 2; then compounds 1 and 4 (each within the scatter of the next).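

In this assay, turning the saturated ring carbon from R to S gives a 790-fold higher number from compound 3 to compound 4 (2.90 log units; beyond the scatter), and nothing else in the structure changes: the fact that compounds 3 and 4 differ only in the configuration as drawn. The material drawn without a configuration at that carbon lies between the two single forms, with a 65-fold higher number from compound 2 to compound 4 (1.81 log units; beyond the scatter). The low number therefore goes with the R form alone, and the S form does not share it.

From the compounds shown here alone, what an ethyl group or a longer chain would do in place of the methyl group on that carbon stays open. Also open, going by these compounds, is whether the same preference holds for compound 1, which is drawn without a configuration there.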